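This account rests on a few compounds, and the source may have more. Where it says the series, first, only, none or still open, it means among the compounds named here.

Working notes on the series. In a functional assay on MIA PaCa-2 cells (Homo sapiens) for cytotoxicity, read by MTT assay (a higher number here means a weaker inhibitor, a lower number a stronger inhibitor), compound 1 (`COc1cc2ncnc(Nc3cc(O)[nH]n3)c2cc1OC`) gives < 100000 nM as a limit. Compound 2 (`COc1cc2ncnc(Nc3cc(-c4ccccc4)[nH]n3)c2cc1OC`) gives < 100000 nM as a limit too. Compound 3 (`COc1cc2ncnc(Nc3cc(-c4ccc(F)cc4)[nH]n3)c2cc1OC`) gives < 100000 nM which is likewise a limit. All three therefore share one reading (the limit of < 100000 nM in this assay, at which 3 of the 3 values shown sit) and none has a number. Compound 4 (`COc1cc2ncnc(Nc3cc(-c4ccc(Cl)cc4)[nH]n3)c2cc1OC`) carries chloro in place of fluoro on an aromatic carbon, para to a large group (chloro in place of fluoro on an aromatic carbon). The measured steps bearing on this change are a step that the two limits leave unreadable from compound 2 to compound 3 and a step that the two limits leave unreadable from compound 1 to compound 3 and neither offers a size to carry over. No shift beyond the scatter is therefore expected in this assay in either direction. The expected change is a step that the limit leaves unreadable from compound 3 to compound 4 on present data. For compound 4 the estimate is 30000 nM with an expected range of 5000 nM to 100000 nM in this read-out.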

Compound 4, half-maximal inhibitory concentration: < 100000 nM
Compound 4 gave a limit, no number (the forecaster's own chance of this, stated with the estimate: 70%); the middle value lies beyond the limit too.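

In this assay no step can be read between compound 4 and compound 1, compound 2 or compound 3, all four values being limits: the limit of < 100000 nM in this assay, at which 4 of the 4 values shown sit.

The compounds shown leave open whether hydroxy, phenyl, 4-fluorophenyl or 4-chlorophenyl differ at all in this read-out.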